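Chloro Substitution Compared Across Two Related Cores

The compounds below may be only part of what the source reports. "The series", "measured", "known", "first", "only" and "open" are said of these compounds alone.

Compound 1 `O=C1NC(=O)/C(=C/c2ccc(OCN3C(=O)c4ccccc4C3=O)cc2)S1` and compound 2 `O=C1NC(=O)/C(=C/c2ccc(OCN3C(=O)c4ccccc4C3=O)c(Cl)c2)S1` share one core, and in an assay on isolated protein for inhibition of Alpha glucosidase (Homo sapiens), read by spectrophotometry, with stated times of 15 min and 30 min (a lower number here means a stronger inhibitor, a higher number a weaker inhibitor), compound 1 gives 25600 nM. In this assay compound 2 gives 21000 nM. Their difference is chloro in place of hydrogen on an aromatic carbon, and it produced a 1.2-fold lower number from compound 1 to compound 2 (0.09 log units; within the scatter). Compound 3 `O=C1NC(=S)S/C1=C\c1ccccc1OCN1C(=O)c2ccccc2C1=O` has another core; the difference between the two cores is not broken down here. In this assay compound 3 is reported only as a limit, > 100000 nM. Compound 4 `O=C1NC(=S)S/C1=C\c1cc(Cl)ccc1OCN1C(=O)c2ccccc2C1=O` differs from compound 3 by chloro in place of hydrogen on an aromatic carbon, the same kind of change, though here the chloro sits para to a large group rather than ortho to it. A small step is expected, a step that the limit leaves unreadable from compound 3 to compound 4, since the earlier step was a 1.2-fold lower number from compound 1 to compound 2 (0.09 log units; within the scatter). Compound 4 is therefore expected near 120000 nM, between 40000 nM and 400000 nM, and because compound 3 stands at the limit of > 100000 nM in this assay, at which 1 of the 3 values shown sits, another limit is likely.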

Compound 4, half-maximal inhibitory concentration: 34800 nM
For compound 4 the middle estimate is 3.4-fold (0.54 log units) above the measured one; measured number below the stated range.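

On the core of compound 3, chloro in place of hydrogen on an aromatic carbon gave an at least 2.8-fold lower number from compound 3 to compound 4 (0.45 log units; beyond the scatter) in this assay, so on this core the change does lower the number. Compound 3 is reported only as a limit, > 100000 nM. The chloro sits at a different place on the two cores, the true size of this step is unknown, and whether the change carries over with the same size from one core to the other stays unsettled: the same change on two cores in this assay, a 1.2-fold lower number (0.09 log units; within the scatter) from compound 1 to compound 2 and an at least 2.8-fold lower number (0.45 log units; beyond the scatter) from compound 3 to compound 4; the limit leaves it open whether they differ

The compounds shown leave open how chloro would behave at other places on either core. They also leave open how a different group on the same carbon, such as a methoxy group or an amine, would compare.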